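Removing one methyl group from compound 3

The compounds below may be only part of what the source reports. "The series", "measured", "known", "first", "only" and "open" are said of these compounds alone.

In a functional assay on the whole organism with Canis familiaris (Canis lupus familiaris) as the target (on this read-out higher numbers stand for an effect only at larger amounts of compound and lower numbers for an effect already at smaller amounts), compound 3 (`COC(=O)CC/C=C\CC[C@H]1C(=O)C[C@@H](O)[C@@H]1/C=C/C[C@@](C)(O)/C=C/C(C)=C(C)C`) gives 0.00006 mg/kg, level with compound 2 (`COC(=O)CC/C=C\CC[C@H]1C(=O)C[C@@H](O)[C@@H]1/C=C/C[C@@](C)(O)/C=C/C=C(C)C`) at 0.00006 mg/kg. Among the measured compounds shown here, these two share the highest number so far, while compound 1 (`C/C=C\C=C\[C@](C)(O)C/C=C/[C@H]1[C@H](O)CC(=O)[C@@H]1CC/C=C\CCC(=O)OC`) gives 0.0000099 mg/kg. Compound 4 (`C/C=C(C)\C=C\[C@](C)(O)C/C=C/[C@H]1[C@H](O)CC(=O)[C@@H]1CC/C=C\CCC(=O)OC`) differs from compound 3 in one group: 1-methylprop-1-en-1-yl in place of 1,2-dimethylprop-1-en-1-yl on a double-bonded chain carbon bound to a double-bonded chain carbon. For the measured compounds named here, two measured steps bear on this. One methyl stays in place, and adding it earlier gave no change at the digits printed from compound 2 to compound 3 (within the scatter). The other methyl is lost, and the group change that brought it in gave a 6.1-fold higher number from compound 1 to compound 2 (0.78 log units; beyond the scatter). Undoing that change should lower the number by a similar amount, so the expected step is a 4.0-fold lower number from compound 3 to compound 4 (0.60 log units; beyond the scatter). For compound 4 the estimated value is 0.000015 mg/kg, with an expected range from 0.000005 mg/kg to 0.00005 mg/kg.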

Compound 4, dose for half-maximal effect: 0.000016 mg/kg
The estimate for compound 4 lay 1.1-fold (0.03 log units) below the measured number; the measured number falls inside the stated range.
By their numbers in this assay, from the lowest: compounds 1 and 4 (each within the scatter of the next); then compounds 2 and 3 (each within the scatter of the next).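

In this assay, going from 1,2-dimethylprop-1-en-1-yl to 1-methylprop-1-en-1-yl gives a 3.8-fold lower number from compound 3 to compound 4 (0.57 log units; beyond the scatter), and going from 2-methylprop-1-en-1-yl to 1-methylprop-1-en-1-yl gives a 3.8-fold lower number from compound 2 to compound 4 (0.57 log units; beyond the scatter). Thus, the number stays lower whenever 1-methylprop-1-en-1-yl replaces either larger group. The methyl on a double-bonded chain carbon bound to two double-bonded chain carbons now has a second test, a 1.6-fold higher number from compound 1 to compound 4 (0.21 log units; within the scatter), and it leaves the number within the scatter on both cores: the same change on two cores in this assay, no change at the digits printed (within the scatter) from compound 2 to compound 3 and a 1.6-fold higher number (0.21 log units; within the scatter) from compound 1 to compound 4, 1.6-fold (0.21 log units) apart, within the scatter of two such steps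

Still open, on these data alone, is how an ethyl or a phenyl group would behave at this place, or a hydroxyl group or an amine.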